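The source may report more compounds than this note shows. Statements on the series, on what has been measured and on what is new or still open speak of the compounds shown alone.

In a functional assay on A549 cells (Homo sapiens) for inhibition, with a stated time of 72 h (a lower number here means a stronger inhibitor, a higher number a weaker inhibitor), compound 2 `O=C(Nc1ccccc1)Nc1nc(NC2CC2)cc(Sc2c[nH]c3ccccc23)n1` gives > 50000 nM, which is a limit of the assay and not a number. For the measured compounds named here, the only true number available comes from compound 1 `COc1ccc(NC(=O)Nc2nc(Sc3c[nH]c4ccccc34)cc(N3CCCCC3)n2)cc1`, which gives 13500 nM in this assay. The next compound to be tested is compound 3 `O=C(Nc1ccccc1)Nc1nc(Sc2c[nH]c3ccccc23)cc(N2CCCC2)n1`, which swaps one group on the shared core: pyrrolidin-1-yl in place of cyclopropylamino on an aromatic carbon. Going by the values given here, no step between two measured compounds is available to size this swap, so any forecast is rough. The expectation rests on compound 1 at 13500 nM, which shows that inhibition can be measured in this family of compounds. A modest move toward stronger inhibition is therefore expected, and the estimated step is an at least 2.0-fold lower number from compound 2 to compound 3 (0.30 log units; that floor lies within the scatter). Compound 3 is estimated at 25000 nM, with an expected range of 10000 nM to 50000 nM.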

Compound 3, half-maximal inhibitory concentration: 21200 nM
Compound 3: middle estimate off by 1.2-fold (0.07 log units), on the high side; the measured number falls inside the stated range.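

In this assay, the group at this position of the shared core now has a visible effect on inhibition: pyrrolidin-1-yl in place of cyclopropylamino gives an at least 2.3-fold lower number from compound 2 to compound 3 (0.37 log units; beyond the scatter). The swap changes the ring size and the number of hydrogen-bond donors at once, so this single step cannot show which of the two matters. Compound 2 stands at a limit and not at a number, so the step has a floor but no known full size: the limit of > 50000 nM in this assay, at which 1 of the 3 values shown sits.

From the compounds shown here alone, what remains open is whether the ring or the missing donor goes with the stronger inhibition. An open-chain group such as dimethylamino, or a ring holding a second hetero atom such as morpholin-4-yl, at this same position would help separate those two changes.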